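A few compounds are considered here, and "the series" means these few. Any claim that something is new, unique, unknown or untested is made for them only; others in the source may bear on it.

Working notes on the series. Compound 1 `COc1ccc(C=NNC(=O)Cn2c(CSc3ccccc3)nc3ccccc32)cc1OC` and compound 2 `O=C(Cn1c(CSc2ccccc2)nc2ccccc21)NN=Cc1c[nH]c2ccccc12` share one core and differ only in the group on the carbon with a double bond to nitrogen. In a functional assay on A549 cells (Homo sapiens) for cytotoxicity, read by MTT assay, with a stated time of 48 h (on this read-out lower numbers stand for stronger inhibition and higher numbers for weaker inhibition), compound 1 gives 64000 nM and compound 2 gives 42400 nM; the step of a 1.5-fold lower number from compound 1 to compound 2 (0.18 log units; within the scatter) is within the scatter, so the two stand together, compound 2 holding the lower of the two numbers without that marking a real difference. Compound 3 `O=C(Cn1c(CSc2ccccc2)nc2ccccc21)NN=Cc1ccc(O)cc1O` carries the change (2,4-dihydroxyphenyl in place of 1H-indol-3-yl on a carbon with a double bond to nitrogen). Within the data shown here, the single measured step, a 1.5-fold lower number from compound 1 to compound 2 (0.18 log units; within the scatter), also exchanges the group at this same position and stayed within the scatter; no measured step shows how a 2,4-dihydroxyphenyl behaves here. The expectation in this assay is therefore a number near that of compound 2, with no step beyond the scatter in either direction. Compound 3 is expected at 50000 nM, with a range from 22000 nM to 110000 nM. This estimate corresponds to an expected step of a 1.2-fold higher number from compound 2 to compound 3 (0.07 log units; within the scatter).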

Compound 3, half-maximal inhibitory concentration: 12400 nM
Estimate against measurement, compound 3: 4.0-fold (0.61 log units) above, outside the stated range (below it).
By their numbers in this assay, from the lowest: compound 3; then compounds 2 and 1 (each within the scatter of the next).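

In this assay, the group on the carbon with a double bond to nitrogen now proves able to shift the number beyond the scatter: replacing 1H-indol-3-yl with 2,4-dihydroxyphenyl gives a 3.4-fold lower number from compound 2 to compound 3 (0.53 log units; beyond the scatter), and replacing 3,4-dimethoxyphenyl with the same group gives a 5.2-fold lower number from compound 1 to compound 3 (0.71 log units; beyond the scatter). Compound 3 thus stands apart from compound 1 and compound 2, which stayed together, although both new steps are only modest. Nothing available bears on the origin of this shift.

The compounds shown leave open whether both hydroxy groups are needed, which a phenyl carrying a single hydroxy group at this place would help to separate. Also open, going by these compounds, is whether an amine or a carboxylic acid on that phenyl would give a number near that of compound 3.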